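The source may report more compounds than this note shows. Statements on the series, on what has been measured and on what is new or still open speak of the compounds shown alone.

Measured compounds:
compound 1 `O=c1c(O)c(O)oc2ccc(Cl)cc12`: 1130000 nM
compound 2 `O=C1C(O)=C(O)OC2CCCCC12`: > 4000000 nM

For the measured compounds named here, compound 1 is the only compound with a numerical result, and in a functional assay on the whole organism for inhibition, with Homo sapiens as the target (a higher number here means a weaker inhibitor, a lower number a stronger inhibitor), compound 1 gives 1130000 nM. Compound 2 reaches only a limit of this assay, > 4000000 nM. So compound 2 stands at the edge of what the numbers show: the limit of > 4000000 nM in this assay, at which 1 of the 2 values shown sits. Compound 3 `O=C1C(O)=C(O)OC2CCCC[C@H]12` differs from compound 2 only in how one centre is drawn: the two compounds have the same atoms and bonds; at least one stereo element is drawn with a configuration in one of them and without one in the other: 1 of 2 stereo elements differ; a stereocentre at a saturated ring carbon is drawn without a configuration in compound 2 and S in compound 3. Going by the values given here, no step between measured compounds is at hand, so the size of the step rests on the change alone, and with the same atoms and bonds no shift in this assay beyond the usual scatter is expected, in either direction. Compound 3 is therefore expected to sit at the same limit, estimated at 5000000 nM with a range of 2000000 nM to 15000000 nM, a step that the limit leaves unreadable from compound 2 to compound 3 that is expected to be nil within the scatter.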

Compound 3, half-maximal inhibitory concentration: > 4000000 nM
Compound 3 was reported as a limit; the forecaster's own chance of this, stated with the estimate: 80%; the middle value does not contradict the limit.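

Compound 2 and compound 3 both reach only a limit in this assay, and no step can be read between them. The compounds shown leave open how far either compound lies past that limit, and whether the drawn configuration at that centre changes the result at all.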